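Compound 3 to compound 4: changing the aryl group

The compounds below may be only part of what the source reports. "The series", "measured", "known", "first", "only" and "open" are said of these compounds alone.

Compound 3 `COc1cc(NC(C)CCCNC(=O)Nc2ccc(F)cc2)c2ncccc2c1` gives 26000 nM in a functional assay on CCRF-CEM cells (Homo sapiens) for inhibition, read by MTT assay, with a stated time of 72 h (a lower number here means a stronger inhibitor, a higher number a weaker inhibitor), and holds the lowest number of the three measured. Compound 1 `COc1cc(NC(C)CCCNC(=O)NNC(=O)Nc2ccc(F)cc2)c2ncccc2c1` gives 118000 nM and compound 2 `COc1cc(NC(C)CCCNC(=O)NNC(=O)Nc2ccc(Cl)cc2)c2ncccc2c1` gives 108000 nM in this assay as well. Compound 4 `COc1cc(NC(C)CCCNC(=O)Nc2cccc(O)c2)c2ncccc2c1` carries 3-hydroxyphenyl in place of 4-fluorophenyl on an amide-type nitrogen, and the difference in full reads 3-hydroxyphenyl in place of 4-fluorophenyl on an amide-type nitrogen here.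

Among the compounds with values here, only one measured step changes a substituent on the aromatic ring: a 1.1-fold lower number from compound 1 to compound 2 (0.04 log units; within the scatter) with chloro in place of fluoro on an aromatic carbon. The two larger steps, a 4.5-fold lower number from compound 1 to compound 3 (0.66 log units; beyond the scatter) and a 4.2-fold lower number from compound 2 to compound 3 (0.62 log units; beyond the scatter), replace a whole ((4-fluorophenyl)carbamoyl)amino or ((4-chlorophenyl)carbamoyl)amino group and say little about the ring. Within the data shown here, no measured compound carries a hydroxy group, so the direction remains open and the margins stay wide. The expected change is a 1.2-fold higher number from compound 3 to compound 4 (0.06 log units; within the scatter) in this assay and no step beyond the scatter is expected. Compound 4 is estimated at 30000 nM with an expected range of 12000 nM to 75000 nM in this assay for now.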

Compound 4, half-maximal inhibitory concentration: 32000 nM
Compound 4: the middle estimate sits 1.1-fold (0.03 log units) below what was measured; the measured number falls inside the stated range.
By their numbers in this assay, from the lowest: compounds 3 and 4 (each within the scatter of the next); then compounds 2 and 1 (each within the scatter of the next).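

In this assay, within the data shown here, 3-hydroxyphenyl in place of 4-fluorophenyl on the amide-type nitrogen gives a 1.2-fold higher number from compound 3 to compound 4 (0.09 log units; within the scatter), so this position takes a hydroxy-bearing ring with no readable change, something the earlier compounds, none of which carries a hydroxy group, could not show. The advantage over the compounds with the longer carbamoylamino groups also holds with the new ring, at a 3.4-fold lower number from compound 2 to compound 4 (0.53 log units; beyond the scatter) and a 3.7-fold lower number from compound 1 to compound 4 (0.57 log units; beyond the scatter), so it is not tied to 4-fluorophenyl. Nothing available explains these results.

The swap changes both the substituent and its ring position, so the effects of the two changes cannot be separated here. As far as these compounds go, it also remains open whether an amine or a carboxylic acid on this ring would move the number beyond the scatter.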